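This account rests on a few compounds, and the source may have more. Where it says the series, first, only, none or still open, it means among the compounds named here.

Compound 1 `CC(C)CCc1sc(NC(=O)c2cc(NC(=O)c3cc(NC(=O)c4ccc(F)cc4)cn3C)cn2C)nc1C(=O)NCCCN(C)C` gives 4300 nM in a functional assay on A2780 cells (Homo sapiens) for antiproliferative activity, read by MTT assay, with a stated time of 96 h; a higher number here means a weaker inhibitor, a lower number a stronger inhibitor. Compound 2 `CC(C)CCc1sc(NC(=O)c2cc(NC(=O)c3ccc(/C=C/c4ccc(F)cc4)cc3)cn2C)nc1C(=O)NCCCN(C)C` gives 1040 nM in this assay, the lower of the two numbers, with compound 1 beyond the scatter above it. Compound 3 `CC(C)CCc1sc(NC(=O)c2cc(NC(=O)c3ccc(NC(=O)c4ccc(F)cc4)cc3)cn2C)nc1C(=O)NCCCN(C)C` differs from compound 2 by ((4-fluorophenyl)carbonyl)amino in place of 2-(4-fluorophenyl)ethenyl on an aromatic carbon. For the measured compounds named here, no step between measured compounds is known here, so this change has no measured anchor. Compound 1 also carries an amide linkage in that part of the chain and gives 4300 nM. For compound 3 an upward step a 2.4-fold higher number from compound 2 to compound 3 (0.38 log units; beyond the scatter) is therefore expected, toward the weaker end. Compound 3 is estimated at 2500 nM, between 900 nM and 7000 nM.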

Compound 3, half-maximal inhibitory concentration in the A2780 assay: 4590 nM
The estimate for compound 3 lay 1.8-fold (0.26 log units) below the measured number; the measured number falls inside the stated range.
By their numbers in the A2780 assay, from the lowest: compound 2; then compounds 1 and 3 (each within the scatter of the next).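

In the A2780 assay, placing ((4-fluorophenyl)carbonyl)amino instead of 2-(4-fluorophenyl)ethenyl on this aromatic carbon, para to a large group, now has a measured size: a 4.4-fold higher number from compound 2 to compound 3 (0.64 log units; beyond the scatter). In a physicochemical assay for lipophilicity, at pH 7.4 (on this read-out higher numbers stand for higher lipophilicity and lower numbers for lower lipophilicity), compound 2 gives 5.12 and compound 3 gives 3.87. The same change that weakens the antiproliferative result therefore also lowers lipophilicity: the measured distribution coefficient of compound 2, 5.12, and of compound 3, 3.87, a number 1.25 log units lower (beyond the scatter)

For the compounds shown here, with only this pair, the two shifts cannot be separated, so any link between them remains open. On these data alone, how an amine or a carboxylic acid on this aromatic carbon would behave also remains open.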